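A few compounds are considered here, and "the series" means these few. Any claim that something is new, unique, unknown or untested is made for them only; others in the source may bear on it.

Working notes on the series. Compound 1 `COc1ccc(CNc2nc([Se]C)nc3ccccc23)cc1` stands at the edge of what a functional assay on HT-29 cells (Homo sapiens) for cytotoxicity, read by MTT assay, with a stated time of 72 h (a lower number here means a stronger inhibitor of growth, a higher number a weaker inhibitor of growth), can report: in this assay compound 1 gives only > 100000 nM, which is a limit and not a number (the limit of > 100000 nM in this assay, at which 1 of the 3 values shown sits). Compound 3 `C[Se]c1nc(NCc2ccccc2)c2ccccc2n1` gives 81000 nM in this assay, and the step of an at least 1.2-fold lower number from compound 1 to compound 3 (0.09 log units; that floor lies within the scatter) does not set compound 1 apart beyond the scatter. Compound 4 `COc1ccc(CNc2nc(SC)nc3ccccc23)cc1` differs from compound 1 by a group of 2 heavy atoms (1 carbon, 1 sulfur; no ring) in place of a group of 2 heavy atoms (1 carbon, 1 selenium; no ring), on an aromatic carbon. For the measured compounds named here, no measured pair isolates this exchange on its own; compound 2 `CSc1nc(NCCCc2ccccc2)c2ccccc2n1`, which also carries methylsulfanyl but with a different amine side chain, gives 89600 nM in this assay, close to the value of compound 3. The expected step is therefore a step that the limit leaves unreadable from compound 1 to compound 4, nothing beyond the scatter. Compound 4 is estimated at 110000 nM in this assay, within 55000 nM to 250000 nM.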

Compound 4, concentration for total growth inhibition: > 100000 nM
Compound 4: no number, only a limit (the forecaster's own chance of this, stated with the estimate: 50%); the middle value is on the limit's open side.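

In this assay compound 1 and compound 4 both give only a limit, not a number, so no step can be read between them: the limit of > 100000 nM in this assay, at which 2 of the 4 values shown sit.
From the compounds shown here alone, whether methylsulfanyl in place of the selenium-bearing group changes growth inhibition on this core remains open.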